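Hydroxyphenyl Position Shift in a Thiol Neprilysin Series

The compounds below may be only part of what the source reports. "The series", "measured", "known", "first", "only" and "open" are said of these compounds alone.

Compound 1 `CC[C@H](C)C(S)C(=O)NCC(=O)N1[C@@H](c2ccccc2)CC[C@H]1C(=O)O`: 50 nM
Compound 2 `Nc1ccc(C[C@H](S)C(=O)NCC(=O)N2[C@@H](c3ccccc3)CC[C@H]2C(=O)O)cc1`: 1.8 nM
Compound 3 `O=C(NCC(=O)N1[C@@H](c2ccccc2O)CC[C@H]1C(=O)O)[C@@H](S)Cc1ccccc1`: 1 nM

In an assay on isolated protein for inhibition of Neprilysin (Oryctolagus cuniculus) (on this read-out higher numbers stand for weaker inhibition and lower numbers for stronger inhibition), compound 3 gives 1 nM. Compound 2 gives 1.8 nM, which lies within the scatter of compound 3, while compound 1 gives 50 nM, far beyond it. Compound 4 `O=C(NCC(=O)N1[C@@H](c2cccc(O)c2)CC[C@H]1C(=O)O)[C@@H](S)Cc1ccccc1` has not yet been measured. It differs from compound 3 by 3-hydroxyphenyl in place of 2-hydroxyphenyl on a saturated ring carbon, the same atoms joined differently.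

Going by the values given here, the only single-point step measured, a 28-fold lower number from compound 1 to compound 2 (1.44 log units; beyond the scatter), concerns the thiol-bearing side chain and not the aryl group on the five-membered ring, so no measured step bears directly on this change. Among the compounds with values here, compounds 2 and 3 differ in two places and give no single step. Without precedent in the series, the shift from 2-hydroxyphenyl to 3-hydroxyphenyl is expected to alter this assay only modestly, and the estimated step of a 2.0-fold higher number from compound 3 to compound 4 (0.30 log units; within the scatter) is accordingly small. Compound 4 is therefore expected to give about 2 nM, within a range from 0.7 nM to 6 nM.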

Compound 4, half-maximal inhibitory concentration: 2.4 nM
Beside the measured number, compound 4's estimate is 1.2-fold (0.08 log units) below it, and the stated range covers the measured number.
By their numbers in this assay, from the lowest: compounds 3, 2 and 4 (each within the scatter of the next, the first and the last beyond it); then compound 1.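

In this assay, the aryl group on the saturated ring carbon next to the ring nitrogen responds to where the hydroxyl sits alone, with the heavy atoms and the counts of hydrogen-bond donors and acceptors unchanged: the step is a 2.4-fold higher number from compound 3 to compound 4 (0.38 log units; beyond the scatter). This step at the aryl group is modest and much smaller than the change at the thiol-bearing side chain, a 28-fold lower number from compound 1 to compound 2 (1.44 log units; beyond the scatter), so this position shows some sensitivity to the shift from 2-hydroxyphenyl to 3-hydroxyphenyl without a large loss. No measurement here accounts for the difference.

Going by these compounds, whether a methoxy group, an amine or a carboxylic acid in place of the hydroxyl would give a larger step remains open. Also open, on these data alone, is whether the same step would hold with the side chain of compound 2.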